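The compounds below may be only part of what the source reports. "The series", "measured", "known", "first", "only" and "open" are said of these compounds alone.

Measured so far:
- compound 1 `CC(Oc1ccccc1Br)C1=NCCN1`: in an assay on CHO cells with Alpha-2C adrenergic receptor (Homo sapiens) as the target (on this read-out lower numbers stand for smaller maximal responses and higher numbers for larger maximal responses), compound 1 gives 0.87
- compound 2 `COc1ccccc1OC(C)C1=NCCN1`: in this assay compound 2 gives 0.6

Among the measured compounds shown here, compound 2 stands lowest of the two numbers known in this assay; its nearest neighbour is compound 1, and the change a number 0.27 lower from compound 1 to compound 2 (beyond the scatter) came with a methoxy in place of a bromo on an aromatic carbon of the shared core.

Compound 3 `CC(Oc1ccccc1S(C)(=O)=O)C1=NCCN1` keeps the whole of compound 2 apart from one group on the ring: methylsulfonyl in place of methoxy on an aromatic carbon. The incoming group sits on an aromatic carbon of a six-membered aromatic ring of carbon only, ortho to a group of 8 heavy atoms.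

For the measured compounds named here, only one measured step bears on this change, and only loosely: a number 0.27 lower from compound 1 to compound 2 (beyond the scatter) shows that swapping the group at this same aromatic carbon can move the maximal response by a modest amount. Going by the values given here, no measured pair shows a methylsulfonyl entering in place of a methoxy, so the direction for compound 3 is open. For compound 3 a step of a number 0.050 lower from compound 2 to compound 3 (within the scatter) is therefore expected, small and within the usual scatter. Compound 3 is estimated at 0.55, within 0.3 to 0.85.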

Compound 3, intrinsic activity: the largest response reached, as a fraction of the reference agonist's: 0.6
Compound 3: the middle estimate sits 0.050 below what was measured; the range from low to high includes it.
By their numbers in this assay, from the lowest: compounds 2 and 3 (each within the scatter of the next); then compound 1.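

In this assay, methylsulfonyl in place of methoxy on this aromatic carbon gives no change at the digits printed from compound 2 to compound 3 (within the scatter), so a group of 4 heavy atoms with 2 double bonds can take the place of a group of 2 heavy atoms and the maximal response stays within the scatter. Bromo now stands apart from both other groups at this carbon: alongside a number 0.27 lower from compound 1 to compound 2 (beyond the scatter) there is a number 0.27 lower from compound 1 to compound 3 (beyond the scatter), and among these three compounds no compound goes against that reading. No measurement at hand explains why methoxy and methylsulfonyl read alike here, or why bromo gives the larger maximal response.

These compounds leave open whether the larger maximal response belongs to bromo alone or would also come with chloro or a methyl group on this carbon, and how an amine or a carboxylic acid there would read in this assay. They also leave open whether the same three groups would keep this order if the shared core were changed elsewhere, for instance with a longer chain in place of its methyl group.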